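Aromatic group changes on the shared core of compound 1

The compounds below may be only part of what the source reports. "The series", "measured", "known", "first", "only" and "open" are said of these compounds alone.

Of the compounds shown here, three have been measured. Compound 1 `Nc1ncnc2c1nc(NCc1cccc(Cl)c1)n2[C@@H]1O[C@H](CO)[C@@H](O)[C@H]1O` gives 5400 nM in an assay on COS-7 cells for inhibition of sodium/nucleoside cotransporter 2 (Homo sapiens), read by scintillation counting, in the presence of a further agent that is not named here; a lower number here means a stronger inhibitor, a higher number a weaker inhibitor. Compound 2 `Nc1ncnc2c1nc(NCc1ccccc1Cl)n2[C@@H]1O[C@H](CO)[C@@H](O)[C@H]1O` gives 5700 nM in this assay, and compound 3 `Nc1ncnc2c1nc(NCc1cccc3ccccc13)n2[C@@H]1O[C@H](CO)[C@@H](O)[C@H]1O` gives 5700 nM. Compound 1 has the lowest of the three numbers, but each gap is within the scatter: a 1.1-fold higher number from compound 1 to compound 2 (0.02 log units; within the scatter), a 1.1-fold higher number from compound 1 to compound 3 (0.02 log units; within the scatter) and no change at the digits printed from compound 2 to compound 3 (within the scatter). No order among compounds 1, 2 and 3 can be read from these.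

Compound 4 `Nc1ncnc2c1nc(NCc1cccc(-c3ccccc3)c1)n2[C@@H]1O[C@H](CO)[C@@H](O)[C@H]1O` is not yet measured. Against compound 1 the change is phenyl in place of chloro on an aromatic carbon. Among the compounds with values here, two measured steps bear on it. The step of a 1.1-fold higher number from compound 1 to compound 3 (0.02 log units; within the scatter) exchanges the 3-chlorophenyl for naphthalen-1-yl on the saturated chain carbon without moving the number beyond the scatter, and the step of a 1.1-fold higher number from compound 1 to compound 2 (0.02 log units; within the scatter) shows that exchanging 3-chlorophenyl for 2-chlorophenyl likewise leaves the number within the scatter. Both indicate that the aromatic group on the chain carbon can be enlarged or altered without a step beyond the scatter in this assay. For compound 4 no step beyond the scatter is therefore expected in this assay, no change at the digits printed from compound 1 to compound 4 (within the scatter). The expected value for compound 4 is 5400 nM, with a range from 2000 nM to 15000 nM.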

Compound 4, half-maximal inhibitory concentration: 21000 nM
Compound 4: middle estimate off by 3.9-fold (0.59 log units), on the low side; the whole stated range lies below it.
By their numbers in this assay, from the lowest: compounds 1, 2 and 3 (each within the scatter of the next); then compound 4.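

In this assay, phenyl in place of chloro on the aromatic carbon gives a 3.9-fold higher number from compound 1 to compound 4 (0.59 log units; beyond the scatter), a modest step and the first in the series to lie beyond the scatter. The earlier exchanges, 2-chlorophenyl in compound 2 and naphthalen-1-yl in compound 3, left the number within the scatter, so their tolerance does not extend to this change, where one chlorine atom leaves and six carbon atoms enter as a further aromatic ring. No measurement available here accounts for the step, and its cause stays unassigned.

The compounds shown leave open whether the step follows the added heavy atoms or the aromatic ring itself; a methyl, a longer chain or a cyclohexyl group on the same carbon would separate these readings. Also open, on these data alone, is whether a phenyl ring carrying an amine or a carboxylic acid would keep, lessen or reverse the step seen with the unsubstituted phenyl group of compound 4.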